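A Hydroxyl Added to the Chlorobenzyl Side Chain

The source may hold more compounds than are shown below. What is called first, only, known or untested is meant among the compounds shown, and "the series" means these compounds.

Among the measured compounds shown here, compound 3 `CC(C)C[C@H](N)c1cc(C(F)(F)F)ccc1N1CCN(C(=O)[C@H](C)Cc2ccc(Cl)cc2)CC1` gives 31 nM in an assay on HEK293 cells for displacement of a labelled ligand from Melanocortin receptor 4 (Homo sapiens) (on this read-out lower numbers stand for stronger inhibition and higher numbers for weaker inhibition), the only plain number among the three values shown here. Compound 1 `CC(C)C[C@H](N)c1cc(C(F)(F)F)ccc1N1CCN(C(=O)C(C)Cc2ccc(Cl)c(Cl)c2)CC1` gives 120 nM; 1600 nM (2 entries) in this assay. Compound 2 `CC(C)C[C@H](N)c1cc(C(F)(F)F)ccc1N1CCN(C(=O)CCC(N)=O)CC1` reaches only the limit of > 10000 nM in this assay. The step of an at least 320-fold lower number from compound 2 to compound 3 (2.50 log units; beyond the scatter) shows how much the chlorobenzyl side chain contributes. Compound 4 `CC(C)C[C@H](N)c1cc(C(F)(F)F)ccc1N1CCN(C(=O)C(C)Cc2ccc(Cl)cc2O)CC1` differs from compound 3 by 1-(4-chloro-2-hydroxybenzyl)ethyl in place of 1-(4-chlorobenzyl)ethyl on a carbonyl carbon. For the measured compounds named here, no measured step tests a hydroxyl on that ring, and compound 4 carries no defined stereocentre, as with compound 1, whose two entries the several entries of compound 1 in this assay, 120 nM; 1600 nM (2 entries) both sit above the value of compound 3. A moderate loss is expected, a 2.9-fold higher number from compound 3 to compound 4 (0.46 log units; beyond the scatter). Compound 4 is estimated at 90 nM, between 20 nM and 500 nM.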

Compound 4, inhibition constant: 36 nM
Beside the measured number, compound 4's estimate is 2.5-fold (0.40 log units) above it; measured number inside the range.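

In this assay, adding the hydroxyl gives a 1.2-fold higher number from compound 3 to compound 4 (0.06 log units; within the scatter), so this side chain takes the extra hydrogen-bond donor and acceptor with no measurable cost. Compound 2 stands at a limit of the assay, > 10000 nM. The hydroxylated side chain still keeps its large gain over 2-carbamoylethyl, with an at least 270-fold lower number from compound 2 to compound 4 (2.44 log units; beyond the scatter).

Going by these compounds, compound 4 has no defined stereocentre, so the value of each single stereoisomer remains open. Also open, on these data alone, is whether a methoxy or an amine in place of the hydroxyl would hold the value.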